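This account rests on a few compounds, and the source may have more. Where it says the series, first, only, none or still open, it means among the compounds named here.

Compound 1 `COc1ccc(OC(=O)Nc2ccc([Se]C#N)cc2)cc1` gives 23700 nM in a functional assay on HTB-54 cells (Homo sapiens) for cytotoxicity, read by MTT assay, with a stated time of 72 h; a lower number here means a stronger inhibitor of growth, a higher number a weaker inhibitor of growth.
Compound 2 `CCCCOC(=O)Nc1ccc([Se]C#N)cc1` gives 17200 nM in this assay.
Compound 3 `CCCCCCOC(=O)Nc1ccc([Se][Se]c2ccc(NC(=O)OCCCCCC)cc2)cc1` gives 31000 nM in this assay.

Compound 2 has the lowest of these three numbers, yet its gap to compound 1 and its gap to compound 3 both sit within the usual scatter, so none of the three can be called stronger than another. Compound 4 `CCCCCCOC(=O)Nc1ccc([Se]C#N)cc1` differs from compound 2 in one place: ethyl in place of hydrogen on a saturated chain carbon, four bonds along the chain from an oxygen next to a carbonyl group. Among the compounds with values here, no step between two measured compounds tracks this change, so there is no measured guide for it; the expectation is a step no larger than the scatter, in either direction. Compound 4 is therefore expected to give about 20000 nM in this assay, within a range of 8000 nM to 50000 nM, which means an estimated step of a 1.2-fold higher number from compound 2 to compound 4 (0.07 log units; within the scatter).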

Compound 4, concentration for 50% growth inhibition: 23600 nM
Compound 4: middle estimate off by 1.2-fold (0.07 log units), on the low side; the measured number falls inside the stated range.
By their numbers in this assay, from the lowest: compounds 2, 4, 1 and 3 (each within the scatter of the next).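

Ethyl in place of hydrogen on this saturated chain carbon now has a measured step, a 1.4-fold higher number from compound 2 to compound 4 (0.14 log units; within the scatter) in this assay, so the chains of these two compounds cannot be told apart in this assay. This single step covers one change on one shared core, and nothing measured here bears on a cause.

From the compounds shown here alone, whether a much longer chain would shift the number beyond the scatter remains open. So does the effect of an amine or a carboxylic acid placed on this same chain carbon.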